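The source may report more compounds than this note shows. Statements on the series, on what has been measured and on what is new or still open speak of the compounds shown alone.

Measured so far:
compound 1, `CC(O)(C(=O)Nc1ccc(S(=O)(=O)c2cccc(F)c2)cc1)C(F)(F)F`: in a functional assay (Cavia porcellus) with sulfonylurea receptors; K-ATP channels (Homo sapiens) as the target (a higher number here means a weaker inhibitor, a lower number a stronger inhibitor), compound 1 gives 3400 nM.
compound 2, `CC(O)(C(=O)Nc1ccc(S(=O)(=O)c2cccc(Cl)c2)cc1)C(F)(F)F`: in this assay compound 2 gives 10000 nM.
compound 3, `Cc1ccccc1S(=O)(=O)c1ccc(NC(=O)C(C)(O)C(F)(F)F)cc1`: in this assay compound 3 gives 5100 nM.

Compound 3 sits close to both others: its steps to compound 1 and to compound 2 both lie within the usual scatter, so none of the three can be ranked against the others. Compound 4, `Cc1ccc(S(=O)(=O)c2ccc(NC(=O)C(C)(O)C(F)(F)F)cc2)cc1`, differs from compound 3 by 4-methylphenyl in place of 2-methylphenyl on a sulfonyl sulfur. For the measured compounds named here, two measured steps bear on a change of the aryl group at the sulfonyl sulfur: a 1.5-fold higher number from compound 1 to compound 3 (0.18 log units; within the scatter) and a 2.0-fold lower number from compound 2 to compound 3 (0.29 log units; within the scatter), both within the scatter. Going by the values given here, the only step beyond the scatter, a 2.9-fold higher number from compound 1 to compound 2 (0.47 log units; beyond the scatter), concerns a halogen exchange, not a change of the methylphenyl. Exchanging one methylphenyl for another is therefore expected to give no step beyond the scatter, a 1.0-fold lower number from compound 3 to compound 4 (0.01 log units; within the scatter). Compound 4 is estimated at 5000 nM, with a range from 2500 nM to 10000 nM.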

Compound 4, half-maximal inhibitory concentration: > 30000 nM
Compound 4 was reported as a limit; the forecaster's own chance of this, stated with the estimate: 5%; middle value at least 6.0-fold (0.77 log units) away from the limit.
By their numbers in this assay, from the lowest: compounds 1, 3 and 2 (each within the scatter of the next, the first and the last beyond it). At a limit, above all of these: compound 4.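

In this assay compound 4 gives > 30000 nM as a limit of the assay, not a number. Moving only the methyl on the aryl group at this sulfonyl sulfur produces a step beyond the scatter (an at least 5.8-fold higher number from compound 3 to compound 4 (0.76 log units; beyond the scatter)), which the earlier changes of this aryl group, all within the scatter, did not show. The 4-methylphenyl group also separates clearly from both halogen-bearing aryl groups (an at least 3.0-fold higher number from compound 2 to compound 4 (0.47 log units; beyond the scatter)) and (an at least 8.8-fold higher number from compound 1 to compound 4 (0.94 log units; beyond the scatter)). The compounds shown leave open how 3-methylphenyl would behave at this sulfur. They also leave open whether a 4-substituted phenyl carrying an amine or a carboxylic acid would give a measurable value.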